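The compounds below may be only part of what the source reports. "The series", "measured", "known", "first", "only" and "open" are said of these compounds alone.

Compound 1 `O=[N+]([O-])c1ccc(Sc2cn(-c3ccc4c(c3)B(O)OC4)c3ccccc23)cc1` gives > 10 ug/mL in an ADME assay on L929 cells (Mus musculus) for cytotoxicity, read by resazurin assay, with a stated time of 72 h; a lower number here means a stronger inhibitor, a higher number a weaker inhibitor.
Compound 2 `Cc1cccc(C(=O)c2ccn(-c3ccc4c(c3)B(O)OC4)c2)c1` gives > 10 ug/mL in this assay.

Both values are limits of this assay rather than measured numbers. Compound 2 stands at the limit of > 10 ug/mL in this assay, at which 2 of the 2 values shown sit, so its own value is only a limit. Compound 3 `Cc1ccsc1C(=O)c1ccn(-c2ccc3c(c2)B(O)OC3)c1` differs from compound 2 in one place: 3-methylthiophen-2-yl in place of 3-methylphenyl on a carbonyl carbon. Among the compounds with values here, no measured pair shows how such a change moves this assay, so a step that the limit leaves unreadable from compound 2 to compound 3 is expected, none beyond the scatter. Compound 3 is therefore estimated at 15 ug/mL in this assay, within 7 ug/mL to 40 ug/mL, most likely reported again only as a limit.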

Compound 3, half-maximal inhibitory concentration: > 10 ug/mL
Compound 3: no number, only a limit; the forecaster's own chance of this, stated with the estimate: 80%; the middle value does not contradict the limit.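

No step can be read from compound 2 to compound 3, since each gives only a limit in this assay: the limit of > 10 ug/mL in this assay, at which 3 of the 3 values shown sit.

The compounds shown leave open where their actual values lie, and whether 3-methylthiophen-2-yl in place of 3-methylphenyl changes anything.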